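Halogen swap on the aryl ring of a thiazolylidene hydrazide

A few compounds are considered here, and "the series" means these few. Any claim that something is new, unique, unknown or untested is made for them only; others in the source may bear on it.

Measured compounds:
compound 1 `O=C(CSc1nnnn1-c1ccccc1)N/N=c1/scc(-c2ccc(Br)cc2)n1-c1ccccc1`: 24.3%
compound 2 `Cc1ccc(-c2cs/c(=N/NC(=O)CSc3nnnn3-c3ccccc3)n2-c2ccccc2)cc1`: 28.5%
compound 3 `O=C(CSc1ncccn1)N/N=c1/scc(-c2ccc(Br)cc2)n1-c1ccccc1`: 67.6%

In a functional assay on C6 cells (Rattus norvegicus) for cytotoxicity, read by MTT assay, with a stated time of 24 h, tested at 100 ug/mL (on this read-out lower numbers stand for a stronger effect and higher numbers for a weaker effect at the one concentration tested), compound 3 stands highest of the three numbers: a number 43.3 percentage points higher from compound 1 to compound 3 (beyond the scatter) lies beyond the scatter, and compound 2 sits well below it too. Compound 4 `O=C(CSc1ncccn1)N/N=c1/scc(-c2ccc(F)cc2)n1-c1ccccc1` keeps the core of compound 3 and differs only in one place: fluoro in place of bromo on an aromatic carbon. For the measured compounds named here, the one measured step that touches this position is a number 4.2 percentage points higher from compound 1 to compound 2 (within the scatter), where methyl took the place of bromo and the number stayed within the scatter. Going by the values given here, that step replaced bromo with a group of a different kind, so it is only an indirect guide, but it is the single precedent and suggests that what stands on this aromatic carbon matters little in this assay. Compound 4 is therefore expected to stay near compound 3, with a step of a number 0.6 percentage points lower from compound 3 to compound 4 (within the scatter) that should not exceed the scatter. The estimated value for compound 4 is 67%, within a range from 50% to 84%.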

Compound 4, a percentage reported as activity, at one concentration (the size of the read-out at that concentration, not a potency): 53.4%
For compound 4 the middle estimate is 13.6 percentage points above the measured one, and the stated range covers the measured number.
By their numbers in this assay, from the lowest: compounds 1 and 2 (each within the scatter of the next); then compound 4; then compound 3.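

In this assay the step of a number 14.2 percentage points lower from compound 3 to compound 4 (beyond the scatter) shows that the group on this aromatic carbon can matter: the change from 4-bromophenyl to 4-fluorophenyl moves the number beyond the scatter, whereas the step of a number 4.2 percentage points higher from compound 1 to compound 2 (within the scatter) stayed within it. The two changes sit on different compounds, one carrying pyrimidin-2-yl on the sulfur and the other 1-phenyl-1H-tetrazol-5-yl, so the data show only that this position is not silent with pyrimidin-2-yl present, and they do not rank fluoro against methyl. Nothing at hand explains the shift.

On these data alone, whether an amine or a methoxy group on this aromatic carbon would stay near bromo or move as fluoro does remains open. So does whether fluoro would shift the number at all with 1-phenyl-1H-tetrazol-5-yl on the sulfur.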